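The source may report more compounds than this note shows. Statements on the series, on what has been measured and on what is new or still open speak of the compounds shown alone.

Of the compounds shown here, three have been measured in an assay on isolated protein for inhibition of 2-Hydroxyacid oxidase 2 (Homo sapiens), tested at 10 uM; a lower number here means a weaker effect, a higher number a stronger effect of the compound at the concentration tested. Compound 1, `Cc1n[nH]c(C(=O)O)c1Cc1cccc(-c2ccc(OC(F)(F)F)cc2)c1`, gives 34%. Compound 2, `Cc1n[nH]c(C(=O)O)c1Cc1cccc(-c2ccccc2F)c1`, gives 22%. Compound 3, `Cc1c(Cc2cccc(-c3ccc(F)cc3)c2)c(C(=O)O)nn1C`, gives 4%. Among these three numbers compound 2 stands second highest: the nearest to it is compound 1, which lies higher by a gap beyond the usual scatter, and the furthest is compound 3, which lies lower, again by a gap beyond the scatter.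

The unmeasured compound 4, `Cc1n[nH]c(C(=O)O)c1Cc1cccc(OC(F)(F)F)c1`, is reached from compound 2 by one change: trifluoromethoxy in place of 2-fluorophenyl on an aromatic carbon. The 2-fluorophenyl is removed and a trifluoromethoxy takes its place on an aromatic carbon of a six-membered aromatic ring of carbon only, meta to a large group. Going by the values given here, no measured pair in this set shows this change, so the size of its effect in this assay is unknown from the data. Both compounds that reach higher numbers in this assay, compound 1 and compound 2, carry a second aromatic ring, and compound 4 does not.

Compound 4 is therefore expected to give a lower number, with the step from compound 2 to compound 4 estimated at a number 10 percentage points lower from compound 2 to compound 4 (within the scatter). The estimate for compound 4 in this assay is 12%, expected to fall between 0% and 28%.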

Compound 4, a percentage reported as inhibition, at one concentration (the size of the read-out at that concentration, not a potency): 26%
Compound 4: the middle estimate sits 14 percentage points below what was measured; the range from low to high includes it.
By their numbers in this assay, from the lowest: compound 3; then compounds 2, 4 and 1 (each within the scatter of the next, the first and the last beyond it).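

Swapping the 2-fluorophenyl for a trifluoromethoxy takes a whole aromatic ring away from this position, yet in this assay the change amounts to a number 4 percentage points higher from compound 2 to compound 4 (within the scatter) and so leaves the read-out effectively unchanged. The second aromatic ring is therefore not needed here to keep the number at this level, and a group with no ring and fewer heavy atoms serves as well as the 2-fluorophenyl. The earlier link between a second ring and the higher numbers does not hold for compound 4, which has no such ring and still stands within the scatter of both compound 1 and compound 2. Nothing in the data explains why two such different groups give matching numbers.

The compounds shown leave open whether a simple methoxy, a chlorine atom or an amine on this aromatic carbon would hold the number as well, which would show how much of the trifluoromethoxy is actually needed. On these data alone, each number also comes from a single tested concentration, so how the potencies of compound 2 and compound 4 compare remains unknown.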